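Swapping a tetrazole for an acetamide on a benzamide scaffold

The compounds below may be only part of what the source reports. "The series", "measured", "known", "first", "only" and "open" are said of these compounds alone.

Two compounds with measurements share a common core. Compound 1 `CC(C)(C)c1ccc(C(=O)NCc2ccc(C(=O)O)cc2F)cc1` in an assay on HeLa cells with Bile acid receptor (Homo sapiens) as the target, read by a luciferase reporter, with a stated time of 24 h (on this read-out lower numbers stand for an effect already at smaller amounts and higher numbers for an effect only at larger amounts of compound), gives 7.8 nM. Compound 2 `CC(C)(C)c1ccc(C(=O)NCc2ccc(-c3nnn[nH]3)cc2)cc1` in this assay gives 120 nM, the higher of the two numbers, and its gap to compound 1 lies well beyond the usual scatter of repeated measurements. Compound 3 `CC(=O)Nc1ccc(CNC(=O)c2ccc(C(C)(C)C)cc2)cc1` has not yet been measured. It differs from compound 2 in one place: acetamido in place of 1H-tetrazol-5-yl on an aromatic carbon. Going by the values given here, no measured pair reproduces exactly this change, so the expectation rests on the two values alone, and the range given must stay wide. The expected step is a moderate rise, a 4.2-fold higher number from compound 2 to compound 3 (0.62 log units; beyond the scatter), meaning that an effect is expected only at somewhat larger amounts of compound. Compound 3 is accordingly estimated at 500 nM, with a plausible span from 100 nM to 3000 nM.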

Compound 3, half-maximal effective concentration: 2900 nM
The estimate for compound 3 lay 5.8-fold (0.76 log units) below the measured number; the range from low to high includes it.
By their numbers in this assay, from the lowest: compound 1; then compound 2; then compound 3.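

In this assay, this position proves far from indifferent to what it carries: acetamido in place of 1H-tetrazol-5-yl gives a 24-fold higher number from compound 2 to compound 3 (1.38 log units; beyond the scatter), a large step. The step appears even though both groups count one hydrogen-bond donor and no net charge; they differ in having or lacking a ring and in their counts of heavy atoms and hydrogen-bond acceptors. Nothing measured here gives a reason for the size of this step.

The single change alters all these features together, so the compounds shown cannot separate the loss of the ring from the loss of acceptors. A simple amine or a propionamido group at the same place would show whether any small group without a ring gives a similarly high number.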